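A Second Trifluoromethyl on the Shared Core

The source may report more compounds than this note shows. Statements on the series, on what has been measured and on what is new or still open speak of the compounds shown alone.

Three measured compounds share a core and differ only at one end. Compound 2 `COc1cc(-c2nn(-c3cccc(NC(=O)Nc4cccc(C(F)(F)F)c4)c3)cc2-c2ccncc2)ccc1Cl` gives 1980 nM in a functional assay on KM12 cells (Homo sapiens) for inhibition, read by sulforhodamine B assay, with a stated time of 48 h; a lower number here means a stronger inhibitor of growth, a higher number a weaker inhibitor of growth. Compound 1 `O=C(Nc1cccc(-n2cc(-c3ccncc3)c(-c3ccc(Cl)c(O)c3)n2)c1)Nc1cc(C(F)(F)F)cc(C(F)(F)F)c1` gives 1430 nM, and compound 3 `COc1cc(-c2nn(-c3cccc(NC(=O)Nc4ccc(Cl)c(C(F)(F)F)c4)c3)cc2-c2ccncc2)ccc1Cl` gives 3920 nM. Compound 2 stands second highest of these three numbers; its nearest neighbour is compound 1 and its furthest is compound 3, both within the usual scatter of such measurements. Among the measured compounds shown here, the one step measured between two compounds that differ in a single place, a 2.0-fold higher number from compound 2 to compound 3 (0.30 log units; within the scatter), stays within the scatter.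

Compound 4 `COc1cc(-c2nn(-c3cccc(NC(=O)Nc4cc(C(F)(F)F)cc(C(F)(F)F)c4)c3)cc2-c2ccncc2)ccc1Cl` has not yet been measured. It differs from compound 2 in one place: trifluoromethyl in place of hydrogen on an aromatic carbon. For the measured compounds named here, no measured step covers exactly this change. Compound 1 carries the same pair of trifluoromethyl groups on a slightly different core, and its number 1430 nM lies close to that of compound 2. The measured step from compound 2 to compound 3 shows that adding a small group at that end moved the number only within the scatter. The expected step is therefore none beyond the scatter, a 1.2-fold lower number from compound 2 to compound 4 (0.07 log units; within the scatter). Compound 4 is estimated at 1700 nM, with a likely range from 800 nM to 3600 nM.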

Compound 4, concentration for total growth inhibition: 1340 nM
The estimate for compound 4 lay 1.3-fold (0.10 log units) above the measured number, within the range that was stated.
By their numbers in this assay, from the lowest: compounds 4, 1, 2 and 3 (each within the scatter of the next, the first and the last beyond it).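

In this assay, trifluoromethyl in place of hydrogen on an aromatic carbon, meta to the trifluoromethyl group already present, gives a 1.5-fold lower number from compound 2 to compound 4 (0.17 log units; within the scatter) and so leaves the number within the scatter even though four heavy atoms enter where there was only a hydrogen. Among the compounds shown here, the result also gives a first direct look at the other end of the molecule with the pair of trifluoromethyl groups held fixed: methyl in place of hydrogen on the oxygen on an aromatic ring gives a 1.1-fold lower number from compound 1 to compound 4 (0.03 log units; within the scatter) and is likewise a step within the scatter, so in this assay the free hydroxyl and its methyl ether cannot be told apart on this scaffold. Nothing measured here offers an explanation for either step.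

The compounds shown leave open whether a group of a different kind at this position, such as an amine or a carboxylic acid, would move the number beyond the scatter. As far as these compounds go, it also remains open whether a longer chain on the oxygen, such as an ethyl group, would do so.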